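Removing the last methyl from the sulfamoyl nitrogen

This account rests on a few compounds, and the source may have more. Where it says the series, first, only, none or still open, it means among the compounds named here.

Compound 1, `CCN1CCCC1CNC(=O)c1cc(N(C)S(=O)(=O)N(C)C)c(C)cc1OC`, gives > 50 mg/kg in a functional assay on the whole organism for inhibition, with Mus musculus as the target; a lower number here means that less compound is needed, a higher number that more compound is needed for the effect; that is a limit of the assay, not a number.
Compound 2, `CCN1CCCC1CNC(=O)c1cc(NS(C)(=O)=O)c(C)cc1OC`, gives 35.6 mg/kg in this assay.
Compound 3, `CCN1CCCC1CNC(=O)c1cc(NS(=O)(=O)NC)c(C)cc1OC`, gives > 50 mg/kg in this assay; that too is a limit of the assay.

Compound 3 therefore stands only at a limit, and it shares that limit with compound 1 (the limit of > 50 mg/kg in this assay, at which 2 of the 3 values shown sit); only compound 2 gives a number. Compound 4, `CCN1CCCC1CNC(=O)c1cc(NS(N)(=O)=O)c(C)cc1OC`, differs from compound 3 in one place: hydrogen in place of methyl on a sulfonamide nitrogen. The closest measured step is the one an at least 1.4-fold higher number from compound 2 to compound 3 (0.14 log units; that floor lies within the scatter), which touched the same sulfamoyl group and moved from a number to a limit. The step that the two limits leave unreadable from compound 1 to compound 3 reveals nothing about size. For the measured compounds named here, no measured step removes a methyl from a sulfamoyl nitrogen, so the direction of the change to compound 4 is unguided by the data. Compound 4 is expected to show a step that the limit leaves unreadable from compound 3 to compound 4, and its value is expected to be a limit again rather than a number. Compound 4 is therefore estimated at 60 mg/kg, within 25 mg/kg to 150 mg/kg.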

Compound 4, dose for half-maximal effect: > 50 mg/kg
Compound 4 gave a limit, no number (the forecaster's own chance of this, stated with the estimate: 70%); the middle value does not contradict the limit.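

Compound 4 adds a second case in this assay where a nitrogen takes the place of the methyl on the sulfonyl sulfur of compound 2, and this change gives an at least 1.4-fold higher number from compound 2 to compound 4 (0.14 log units; that floor lies within the scatter). With amino as with methylamino on that sulfur, the result is a limit and not a number, so removing the methyl from the sulfonamide nitrogen does not restore a number. The steps from compound 3 and from compound 1 to compound 4 cannot be read, and only compound 2 remains with a number: the limit of > 50 mg/kg in this assay, at which 3 of the 4 values shown sit.

From the compounds shown here alone, whether compound 1, compound 3 and compound 4 differ from one another beyond that limit stays open. Going by these compounds, it is also open whether ethyl or a longer chain on the sulfonyl sulfur, in place of the methyl of compound 2, would give a number.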